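Tolerated Concentrations Across a Shared Core

The source may report more compounds than this note shows. Statements on the series, on what has been measured and on what is new or still open speak of the compounds shown alone.

The measured compounds and their values:
compound 1 `Nc1nc(NCc2ccccc2)c2ncn(/C=C3/CC3(CO)CO)c2n1`
compound 2 `COCCOc1nc(N)nc2c1ncn2/C=C1/CC1(CO)CO`
compound 3 `CCCCCCOc1nc(N)nc2c1ncn2/C=C1/CC1(CO)CO`

In an ADME assay on Akata cells (Homo sapiens) for cytotoxicity, with a stated time of 7 days (a higher number here means that more compound is tolerated, a lower number that less compound is tolerated), compound 1 gives > 24000 nM, which is a limit of the assay and not a number. Compound 2 gives > 20000 nM, likewise a limit. Compound 3 gives > 20000 nM, again a limit. Compound 3 therefore sits at the limit of > 20000 nM in this assay, at which 2 of the 3 values shown sit, together with compound 2, while compound 1 sits at the limit of > 24000 nM in this assay, at which 1 of the 3 values shown sits. None of the three steps between these compounds can be read: a step that the two limits leave unreadable from compound 1 to compound 2, a step that the two limits leave unreadable from compound 1 to compound 3 and a step that the two limits leave unreadable from compound 2 to compound 3 all run between two limits, so their size is not known.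

Compound 4 is `CC(C)Sc1nc(N)nc2c1ncn2/C=C1/CC1(CO)CO`. It differs from compound 3 in one place: isopropylsulfanyl in place of hexyloxy on an aromatic carbon. Among the measured compounds shown here, the steps that bear on this change are the ones just named, and since each is unreadable, no size or direction can be drawn from them; what they do show is that three different groups at the same position on the shared core all leave the compounds tolerated up to the limit. For compound 4 the same outcome is expected, with the step that the limit leaves unreadable from compound 3 to compound 4 estimated to stay within the scatter. Compound 4 is therefore expected to give about 25000 nM, in a range from 8000 nM to 80000 nM.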

Compound 4, half-maximal cytotoxic concentration: > 20000 nM
Compound 4 gave a limit, no number; the forecaster's own chance of this, stated with the estimate: 80%; the middle value does not contradict the limit.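

In this assay compound 4 gives > 20000 nM, which is a limit and not a number. Its steps to compound 1, compound 2 and compound 3 all run between two limits, so none can be read. The compounds shown leave open at what concentration any of the four stops being tolerated, and whether the group on the aromatic carbon matters.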